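Hydrazide series on the shared core: sulfonamide antiproliferatives

The compounds below may be only part of what the source reports. "The series", "measured", "known", "first", "only" and "open" are said of these compounds alone.

Among the measured compounds shown here, compound 1 `O=C(NNc1cccc(Cl)c1)c1ccc(NS(=O)(=O)c2cnc(O)nc2O)cc1` is the only member with a numeric result: in a functional assay on OVCAR-3 cells (Homo sapiens) for antiproliferative activity, read by MTT assay, with a stated time of 24 h (a higher number here means a weaker inhibitor, a lower number a stronger inhibitor), compound 1 gives 8410 nM. Compound 2 `Cc1ccccc1NNC(=O)c1ccccc1NS(=O)(=O)c1cnc(O)nc1O` reaches only the limit of this assay, > 20000 nM, a limit and not a number, as set out in the limit of > 20000 nM in this assay, at which 1 of the 2 values shown sits. Compound 3 `O=C(NNC(=O)c1ccc(NS(=O)(=O)c2cnc(O)nc2O)cc1)c1ccc(F)cc1` differs from compound 1 by (4-fluorophenyl)carbonyl in place of 3-chlorophenyl on an amine nitrogen. For the measured compounds named here, no measured pair frames this change, so the step is expected to stay near the scatter, a 1.3-fold higher number from compound 1 to compound 3 (0.12 log units; within the scatter), with a small drift toward weaker inhibition. Compound 3 is estimated at 11000 nM in this assay, between 3500 nM and 30000 nM.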

Compound 3, half-maximal inhibitory concentration: > 20000 nM
Compound 3: no number, only a limit; the forecaster's own chance of this, stated with the estimate: 30%; middle value at least 1.8-fold (0.25 log units) from the limit.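

Among the compounds shown here, on the amine nitrogen, the change to (4-fluorophenyl)carbonyl from 3-chlorophenyl gives an at least 2.3-fold higher number from compound 1 to compound 3 (0.37 log units; beyond the scatter) in this assay, the first step and one beyond the scatter, so this position is not indifferent to substitution. Compound 3 gives > 20000 nM, a limit and not a number, so the full size of the step cannot be read. Limits now outnumber numbers in the series: the limit of > 20000 nM in this assay, at which 2 of the 3 values shown sit.

Going by these compounds, whether the carbonyl or the ring substituent carries the shift remains open, and (3-chlorophenyl)carbonyl on the same nitrogen would separate them. On these data alone, how a longer chain or a carboxylic acid would read at this position also remains open.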